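Phenyl in Place of Methyl on an Amide Chain

The source may report more compounds than this note shows. Statements on the series, on what has been measured and on what is new or still open speak of the compounds shown alone.

Compound 1 `CCCCNC(=O)C1C(C(=O)O)[C@@H]2CC[C@H]1O2` and compound 2 `CCOC(=O)c1cn[nH]c1NC(=O)C1C(C(=O)O)[C@@H]2CC[C@H]1O2` share the same core, each carrying a carboxylic acid and an amide. In an ADME assay on SW480 cells (Homo sapiens) for cytotoxicity, read by MTT assay, with a stated time of 72 h (a higher number here means a weaker inhibitor of growth, a lower number a stronger inhibitor of growth), compound 1 gives 10000 nM. In this assay compound 2 gives 10000 nM. Compound 1 therefore stands level with compound 2 at the digits shown, the two values lying within the scatter of each other.

Compound 3 `O=C(O)C1C(C(=O)NCCCc2ccccc2)[C@H]2CC[C@@H]1O2` has not yet been measured in this assay. It differs from compound 1 by phenyl in place of methyl on a saturated chain carbon, three bonds along the chain from an amide-type nitrogen. For the measured compounds named here, no step between measured compounds is available, so this change has no anchor in the measured pair, and the two measured values leave the effect of the chain open. A step of modest size, if any, is expected for compound 3, toward stronger inhibition of growth, a 1.4-fold lower number from compound 1 to compound 3 (0.15 log units; within the scatter). Compound 3 is estimated at 7000 nM, expected to fall between 2500 nM and 20000 nM.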

Compound 3, concentration for 50% growth inhibition: 10000 nM
Compound 3: the middle estimate sits 1.4-fold (0.15 log units) below what was measured, and the stated range covers the measured number.
By their numbers in this assay, from the lowest: compounds 1, 2 and 3 (each within the scatter of the next).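

For the compounds shown here, the step of no change at the digits printed from compound 1 to compound 3 (within the scatter) in this assay is the first one read at this position, and it shows that phenyl in place of methyl on a saturated chain carbon, three bonds along the chain from an amide-type nitrogen, leaves the number unchanged at the digits printed. Going by these compounds alone, the earlier pair could not show this, since compound 1 and compound 2 differ in more than one place and gave no step. No independent measurement bears on this result, so it stands without any explanation.

The shown compounds leave open whether an amine, a hydroxyl or a pyridine in place of the phenyl would move the number in this assay. They also leave open whether a longer chain would do so.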